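A Fluoro Added to the Aromatic Ring of Compound 1

A few compounds are considered here, and "the series" means these few. Any claim that something is new, unique, unknown or untested is made for them only; others in the source may bear on it.

Compound 1: `C=CC[C@H]1C[C@]2([C@@H](C)Cc3ccc(OC)c(NC(C)=O)c3)OCOC2=CC1=O`, 85 nM
Compound 2: `C=CC[C@H]1C[C@]2([C@@H](C)Cc3ccc(OC)c(F)c3)OCOC2=CC1=O`, 8 nM

In a functional assay on M14 cells (Homo sapiens) for antiproliferative activity, with a stated time of 72 h (a higher number here means a weaker inhibitor, a lower number a stronger inhibitor), compound 1 stands highest of the two numbers; compound 2 sits an 11-fold lower number from compound 1 to compound 2 (1.03 log units; beyond the scatter), a large step made by a different change. Compound 3, `C=CC[C@H]1C[C@]2([C@@H](C)Cc3cc(NC(C)=O)c(OC)cc3F)OCOC2=CC1=O`, differs from compound 1 by fluoro in place of hydrogen on an aromatic carbon, keeping the acetamido group. Among the measured compounds shown here, no measured step adds a fluoro while leaving the acetamido in place, so the step from compound 1 to compound 2 bears only loosely on it. A small gain, possibly within the scatter, is expected, a 1.4-fold lower number from compound 1 to compound 3 (0.15 log units; within the scatter). Compound 3 is estimated at 60 nM, ranging from 20 nM to 180 nM.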

Compound 3, half-maximal inhibitory concentration: 52 nM
Beside the measured number, compound 3's estimate is 1.2-fold (0.06 log units) above it; measured number inside the range.
By their numbers in this assay, from the lowest: compound 2; then compounds 3 and 1 (each within the scatter of the next).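

In this assay, fluoro in place of hydrogen on this aromatic carbon, ortho to a large group and para to an acetamido group, gives a 1.6-fold lower number from compound 1 to compound 3 (0.21 log units; within the scatter). The earlier compounds shown here differed only at the acetamido group, whereas this pair shows that the added fluoro leaves the number indistinguishable with the acetamido group kept. Nothing available bears on why this is so.

The compounds shown leave open whether a chloro or methyl group on this carbon would read the same. From the compounds shown here alone, whether this fluoro would have the same outcome on compound 2 also remains open.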